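The source may hold more compounds than are shown below. What is called first, only, known or untested is meant among the compounds shown, and "the series" means these compounds.

Measured so far:
- compound 1, `COC(=O)c1c(Br)cc(Br)cc1OC(=O)COc1cc(O)c2c(=O)cc(-c3ccccc3)oc2c1`: 45700 nM in a functional assay on cells (T-cell, Mus musculus, strain BALB/c) for inhibition, read by MTT assay, with a stated time of 72 h; a lower number here means a stronger inhibitor, a higher number a weaker inhibitor
- compound 2, `COC(=O)c1cc(O)ccc1OC(=O)COc1cc(O)c2c(=O)cc(-c3ccccc3)oc2c1`: 29500 nM in this assay

Compound 2 has the lower of the two numbers, but compound 1 sits within the scatter of it, so the two values show no difference that can be read as an order. Going by the values given here, both compounds share the same core and differ only in the substitution of the ester-bearing ring; no step between them is recorded, so their two values are all that is known.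

Compound 3, `COC(=O)c1cc(Br)ccc1OC(=O)COc1cc(O)c2c(=O)cc(-c3ccccc3)oc2c1`, is not yet measured. It differs from compound 2 by bromo in place of hydroxy on an aromatic carbon.

Among the compounds with values here, with no recorded step to rest on, and compound 1 and compound 2 within the scatter of each other, no step beyond the scatter is expected in this assay for this change, in either direction. Compound 3 is expected to give 35000 nM, within 15000 nM to 80000 nM. The step this estimate means, a 1.2-fold higher number from compound 2 to compound 3 (0.07 log units; within the scatter), is expected to lie within the scatter.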

Compound 3, half-maximal inhibitory concentration: 780 nM
For compound 3 the middle estimate is 45-fold (1.65 log units) above the measured one; measured number outside the range, below it.
By their numbers in this assay, from the lowest: compound 3; then compounds 2 and 1 (each within the scatter of the next).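

In this assay, the position para to a large group and meta to a methoxycarbonyl group is sensitive to substitution: bromo in place of hydroxy gives a 38-fold lower number from compound 2 to compound 3 (1.58 log units; beyond the scatter) on an otherwise unchanged structure. Going by these compounds alone, compound 1 and compound 2 differ in more than one place and lie within the scatter of each other, so this single exchange is the first clean reading of the position, and it shows that the series can move well beyond the scatter through one aromatic substituent. Nothing available accounts for the size of this step.

Still open, from the compounds shown here alone, is whether the step follows from the arrival of bromo or the departure of hydroxy, which plain hydrogen, chloro or methyl at this position could help separate. An amine or a carboxylic acid there would test how far the position tolerates other kinds of group.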